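Removing the phenylsulfonyl group from compound 3

A few compounds are considered here, and "the series" means these few. Any claim that something is new, unique, unknown or untested is made for them only; others in the source may bear on it.

Measured in a functional assay on HCT-116 cells (Homo sapiens) for inhibition; a higher number here means a weaker inhibitor, a lower number a stronger inhibitor:
Compound 1 `FC(F)(F)Oc1cccc(/C=C\c2ccc3ccccc3c2)c1`: 3500 nM
Compound 2 `O=S(=O)(c1ccccc1)n1ccc2cc(/C=C/c3ccc4ccccc4c3)ccc21`: > 5000 nM, a limit
Compound 3 `O=S(=O)(c1ccccc1)n1ccc2cc(/C=C\c3ccc4ccccc4c3)ccc21`: > 5000 nM, a limit

Compound 3 has no number of its own. Its result, > 5000 nM, is a limit, and it stands at the limit of > 5000 nM in this assay, at which 2 of the 3 values shown sit.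

Compound 4 `C(=C\c1ccc2[nH]ccc2c1)\c1ccc2ccccc2c1` differs from compound 3 by hydrogen in place of phenylsulfonyl on an aromatic nitrogen, with hydrogen in place of phenylsulfonyl on an aromatic nitrogen.

Going by the values given here, the one measured step, a step that the two limits leave unreadable from compound 2 to compound 3, rests on the fact that compounds 2 and 3 differ only in the configuration as drawn and gives no size for a change at the nitrogen. Among the compounds with values here, the only reading with a number comes from compound 1, which carries no phenylsulfonyl, at 3500 nM. On that thin basis, a move towards stronger inhibition in this assay is expected, of uncertain size, and another limit remains possible. The expected step is an at least 1.6-fold lower number from compound 3 to compound 4 (0.22 log units; that floor lies within the scatter). For compound 4 the estimate is 3000 nM, with an expected range from 700 nM to 8000 nM.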

Compound 4, half-maximal inhibitory concentration: > 5000 nM
Compound 4: a limit, no number (the forecaster's own chance of this, stated with the estimate: 35%); middle value at least 1.6-fold (0.22 log units) away from the limit.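

In this assay compound 4 gives > 5000 nM, which is a limit. Compound 3 also gives a limit, and the step between compound 3 and compound 4 cannot be read. The compounds shown leave open whether hydrogen in place of phenylsulfonyl changes inhibition at all.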